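Cyano for chloro in the shared core: cytotoxicity notes

This account rests on a few compounds, and the source may have more. Where it says the series, first, only, none or still open, it means among the compounds named here.

Measured so far in an ADME assay on RAW264.7 cells (Mus musculus) for cytotoxicity, read by MTT assay, with a stated time of 48 h; a higher number here means a weaker inhibitor, a lower number a stronger inhibitor:
compound 1, `CS(=O)(=O)Nc1ccc(NC(=O)c2ccc(Cl)cc2)cc1Cl`, 79900 nM
compound 2, `CS(=O)(=O)Nc1ccc(NC(=O)c2ccc(C#N)cc2)cc1Cl`, a limit of the assay, > 250000 nM
compound 3, `O=C(Nc1ccc(NS(=O)(=O)C(F)(F)F)c(Cl)c1)c1ccc(Cl)cc1`, 47200 nM

Compound 2 reaches only a limit in this assay, (the limit of > 250000 nM in this assay, at which 1 of the 3 values shown sits). The two cores differ by trifluoromethyl in place of methyl on a sulfonyl sulfur; the step that this makes is a 1.7-fold lower number from compound 1 to compound 3 (0.23 log units; within the scatter). From compound 1 to compound 2 the change is cyano in place of chloro on an aromatic carbon, and the step is an at least 3.1-fold higher number from compound 1 to compound 2 (0.49 log units; beyond the scatter).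

Compound 4, `N#Cc1ccc(C(=O)Nc2ccc(NS(=O)(=O)C(F)(F)F)c(Cl)c2)cc1`, is not yet measured. Its difference from compound 3 is cyano in place of chloro on an aromatic carbon, the same change as from compound 1 to compound 2, and the place lines agree word for word. The step expected in this assay is a 3.8-fold higher number from compound 3 to compound 4 (0.58 log units; beyond the scatter), an expectation resting on the measured pair, where compound 1 to compound 2 gave an at least 3.1-fold higher number from compound 1 to compound 2 (0.49 log units; beyond the scatter); since compound 2 sits at a limit, the true size of that step is not known, and compound 4 may also reach the limit. Compound 4 is estimated at 180000 nM, within 90000 nM to 400000 nM.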

Compound 4, half-maximal inhibitory concentration: > 250000 nM
Compound 4 ended at the assay's limit; the forecaster's own chance of this, stated with the estimate: 45%; middle value at least 1.3-fold (0.14 log units) from the limit.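

In this assay, cyano in place of chloro moves the number in the same direction on the core of compound 3 as on the core of compound 1, with an at least 5.2-fold higher number from compound 3 to compound 4 (0.72 log units; beyond the scatter). Compound 4 gives > 250000 nM, a limit of the assay and not a number, and the step between compound 2 and compound 4, which both stand at limits, cannot be read. The two cores therefore show a shared direction for this change, but not a shared size: the same change on two cores in this assay, an at least 3.1-fold higher number (0.49 log units; beyond the scatter) from compound 1 to compound 2 and an at least 5.2-fold higher number (0.72 log units; beyond the scatter) from compound 3 to compound 4; the limit leaves it open whether they differ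

The compounds shown leave open how far the number rises with cyano on either core, and whether an amine or a carboxylic acid in place of chloro on that aromatic carbon would move it the same way. Also open, as far as these compounds go, is whether the change carries over when a longer chain replaces methyl or trifluoromethyl on the sulfonyl sulfur.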